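From phenyl to 4-fluorophenyl in compound 4

The source may hold more compounds than are shown below. What is called first, only, known or untested is meant among the compounds shown, and "the series" means these compounds.

Compound 1 `OC[C@H]1O[C@@H](n2cc(F)c3c(-c4ccccc4)ncnc32)[C@H](O)[C@@H]1O`: > 50000 nM, a limit
Compound 2 `OC[C@H]1O[C@@H](n2cc(F)c3c(-c4c[nH]cn4)ncnc32)[C@H](O)[C@@H]1O`: > 50000 nM, a limit
Compound 3 `OC[C@H]1O[C@@H](n2cc(Cl)c3c(-c4ccccc4)ncnc32)[C@H](O)[C@@H]1O`: 44500 nM

Going by the values given here, in an ADME assay on BJ cells (Homo sapiens) for cytotoxicity, read by MTT assay, with a stated time of 72 h (on this read-out lower numbers stand for higher toxicity in this test and higher numbers for lower toxicity in this test), compound 3 gives 44500 nM, the only value among the three that is an actual number and not a limit. Compound 4 `OC[C@H]1O[C@@H](n2cc(Cl)c3c(-c4ccc(F)cc4)ncnc32)[C@H](O)[C@@H]1O` has fluoro in place of hydrogen on an aromatic carbon. Two measured steps offer some context, though neither changes this position in the same way. Among the compounds with values here, the first is a step that the two limits leave unreadable from compound 1 to compound 2, and the second is an at least 1.1-fold lower number from compound 1 to compound 3 (0.05 log units; that floor lies within the scatter). With so little readable evidence, no shift beyond the scatter is expected in either direction. The expected change is a 1.1-fold lower number from compound 3 to compound 4 (0.05 log units; within the scatter). The estimated value for compound 4 is 40000 nM, with an expected range from 18000 nM to 50000 nM.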

Compound 4, half-maximal cytotoxic concentration: 49500 nM
Beside the measured number, compound 4's estimate is 1.2-fold (0.09 log units) below it, and the stated range covers the measured number.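

Phenyl to 4-fluorophenyl gives a 1.1-fold higher number from compound 3 to compound 4 (0.05 log units; within the scatter) in this assay, so fluoro at this place on the ring leaves the number within the scatter. This is the first step among these compounds with a real number at both ends, and it is the first change made on the phenyl ring itself. The number for compound 4 still stands close to the top of what the test can read: the limit of > 50000 nM in this assay, at which 2 of the 4 values shown sit.

An amine or a carboxylic acid at this same place could still shift the number beyond the scatter. Going by these compounds, whether fluoro here behaves alike on the core of compound 1 also remains open.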